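Moving a dichloroaryl ring one carbon out on a urea

A few compounds are considered here, and "the series" means these few. Any claim that something is new, unique, unknown or untested is made for them only; others in the source may bear on it.

Compound 1 `Cc1cc(NC(=O)Nc2cc(Cl)cc(Cl)c2)ccc1N1CCC(N2CCCC2C)C1`: 43 nM
Compound 2 `CC1CCCN1C1CCN(c2ccc(NC(=O)N3CCN(c4ccccc4)CC3)cc2)C1`: 10.6 nM

Of the compounds shown here, two have been measured in an assay on CHO cells for displacement of a labelled ligand from histamine receptor H3 (Macaca mulatta), read by scintillation counting, with a stated time of 1 h; a higher number here means a weaker inhibitor, a lower number a stronger inhibitor. Compound 1 gives 43 nM, the higher of the two numbers, and compound 2 gives 10.6 nM; the gap between them lies beyond the scatter, so compound 2 is the stronger inhibitor of the pair. The two differ in several places at once, so no single change accounts for that gap.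

Compound 3 `Cc1cc(NC(=O)NCc2cc(Cl)cc(Cl)c2)ccc1N1CCC(N2CCCC2C)C1` is not yet measured. It differs from compound 1 in one place: 3,5-dichlorobenzyl in place of 3,5-dichlorophenyl on an amide-type nitrogen. The shared core of compound 1 is kept; only the group on the urea nitrogen shifts outward by one carbon. Within the data shown here, with no measured pair showing this kind of change, the direction is uncertain; a modest step either way, or none beyond the scatter, seems plausible. The expected step in this assay is a 1.2-fold higher number from compound 1 to compound 3 (0.07 log units; within the scatter). Compound 3 is estimated at 50 nM, within a range from 12 nM to 200 nM.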

Compound 3, inhibition constant: 28.8 nM
The estimate for compound 3 lay 1.7-fold (0.24 log units) above the measured number; the range from low to high includes it.
By their numbers in this assay, from the lowest: compound 2; then compounds 3 and 1 (each within the scatter of the next).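

Among these compounds, this is the first change at a single place that can be read in this assay. Placing 3,5-dichlorobenzyl in place of 3,5-dichlorophenyl on the amide-type nitrogen gives a 1.5-fold lower number from compound 1 to compound 3 (0.17 log units; within the scatter), so moving the ring outward by one carbon on this urea leaves the number within the usual scatter. Nothing measured here speaks to why the step is this small.

Still open, from the compounds shown here alone, is whether the number stays within the scatter when a longer chain holds the same dichlorinated ring on this nitrogen, or when a plain benzyl or a pyridylmethyl group stands there instead. This one pair also cannot show whether the added carbon would have a similar effect on a different core.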